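The source may report more compounds than this note shows. Statements on the series, on what has been measured and on what is new or still open speak of the compounds shown alone.

Compound 1 (`CC[C@H](N)C(=O)N[C@@H]1C(=O)N2[C@@H](CC[C@@H]1CCO)CC[C@H]2C(=O)NC(c1ccccc1)c1ccccc1`) gives no number in a functional assay on PC-3 cells (Homo sapiens) for cytotoxicity, read by MTT assay, with a stated time of 96 h; a lower number here means a stronger inhibitor, a higher number a weaker inhibitor: its result, > 100000 nM, is a limit. Compound 2 (`CCNCC[C@H]1CC[C@H]2CC[C@@H](C(=O)NC(c3ccccc3)c3ccccc3)N2C(=O)[C@H]1NC(=O)[C@H](CC)NC`) likewise returns only a limit, > 100000 nM. Within the data shown here, the series so far stands at the limit of > 100000 nM in this assay, at which 2 of the 2 values shown sit. Compound 3 (`CC[C@H](N)C(=O)N[C@@H]1C(=O)N2[C@@H](CC[C@@H]1CCNCc1ccccc1)CC[C@H]2C(=O)NC(c1ccccc1)c1ccccc1`) has benzylamino in place of hydroxy on a saturated chain carbon, two bonds along the chain from a saturated ring carbon. Among the measured compounds shown here, no measured step gives a size for this change, so only a small move toward a lower number is expected in this assay, and a further limit remains likely. The expected step is an at least 1.6-fold lower number from compound 1 to compound 3 (0.22 log units; that floor lies within the scatter). For compound 3 the estimated value is 60000 nM, with an expected range of 15000 nM to 150000 nM.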

Compound 3, half-maximal inhibitory concentration: 39200 nM
Beside the measured number, compound 3's estimate is 1.5-fold (0.18 log units) above it, and the stated range covers the measured number.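

In this assay, among these compounds, this change at the chain end gives the first real number, with an at least 2.5-fold lower number from compound 1 to compound 3 (0.40 log units; beyond the scatter). The step is only a floor, as compound 1 carries a limit, so its full size cannot be read. The position therefore tolerates the larger benzylamino group and responds to it, while most of the series stays at the limit: the limit of > 100000 nM in this assay, at which 2 of the 3 values shown sit.

From the compounds shown here alone, whether the nitrogen or the aromatic ring of benzylamino carries the step remains open. A primary amine or a phenethylamino group on the same chain would help separate the two.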